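The source may report more compounds than this note shows. Statements on the series, on what has been measured and on what is new or still open speak of the compounds shown alone.

Compound 1 `COc1ccc(N(C)c2ccnc(Cl)n2)cc1F`: 914 nM
Compound 2 `COc1ccc(N(C)c2cc(C)nc(C)n2)cc1F`: 584 nM

In a functional assay on HCT-116 cells (Homo sapiens) for antiproliferative activity, read by MTT assay, with a stated time of 48 h (a lower number here means a stronger inhibitor, a higher number a weaker inhibitor), compound 2 gives 584 nM, the lower of the two numbers, but compound 1 gives 914 nM, and the two lie within the usual scatter of each other. Compound 3 `COc1ccc(N(C)c2cc(C)nc(C)n2)cc1[N+](=O)[O-]` has nitro in place of fluoro on an aromatic carbon, ortho to a methoxy group, compared with compound 2: nitro in place of fluoro on an aromatic carbon. Among the measured compounds shown here, no measured pair shows the effect of a single change, so there is little basis for predicting a direction in this assay. The expected change is a 1.2-fold higher number from compound 2 to compound 3 (0.08 log units; within the scatter), no more than the usual scatter. Compound 3 is estimated at 700 nM, with an expected range of 180 nM to 2700 nM.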

Compound 3, half-maximal inhibitory concentration: 4670 nM
Beside the measured number, compound 3's estimate is 6.7-fold (0.82 log units) below it; the whole stated range lies below it.
By their numbers in this assay, from the lowest: compounds 2 and 1 (each within the scatter of the next); then compound 3.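

In this assay, among the compounds shown here, replacing fluoro with nitro on the aromatic carbon ortho to a methoxy group gives an 8.0-fold higher number from compound 2 to compound 3 (0.90 log units; beyond the scatter), the first single change that can be read here. The result shows that this position is sensitive to what it carries, since this one swap moves the number beyond the scatter. No measurement at hand accounts for the shift.

With only fluoro and nitro compared at this position, one step cannot show how other groups would behave. An amine or a carboxylic acid there remains an open case.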